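The source may hold more compounds than are shown below. What is called first, only, known or untested is meant among the compounds shown, and "the series" means these compounds.

Three stilbene-type compounds have been measured so far. Compound 1 `Nc1ccccc1/C=C/c1cccc(O)c1` gives 30 ug/mL in a functional assay on HT-29 cells (Homo sapiens) for inhibition, read by MTT assay, with a stated time of 2 days; on this read-out higher numbers stand for weaker inhibition and lower numbers for stronger inhibition. Compound 2 `Nc1cccc(/C=C/c2cccc(O)c2)c1` has the same atoms as compound 1 joined differently; the difference between the two cores is not broken down here. In this assay compound 2 gives 43 ug/mL, the highest of the three numbers, and its gap to compound 1 is within the scatter. Compound 3 `COc1ccccc1/C=C/c1cccc(O)c1` gives 17 ug/mL. The change from compound 1 to compound 3 is methoxy in place of amino on an aromatic carbon, and it gave a 1.8-fold lower number from compound 1 to compound 3 (0.25 log units; within the scatter).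

Compound 4 `COc1cccc(/C=C/c2cccc(O)c2)c1` has not yet been measured. It differs from compound 2 by methoxy in place of amino on an aromatic carbon; the place lines differ in that the group sits ortho to the nine-heavy-atom group in the first case and meta to it in the second, so this is the same kind of change rather than the same change. Because the earlier step of a 1.8-fold lower number from compound 1 to compound 3 (0.25 log units; within the scatter) was small, compound 4 is expected to sit at a 1.8-fold lower number from compound 2 to compound 4 (0.25 log units; within the scatter) from compound 2. The number expected for compound 4 is 24 ug/mL, with a range from 12 ug/mL to 50 ug/mL.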

Compound 4, half-maximal inhibitory concentration: 11.5 ug/mL
Estimate against measurement, compound 4: 2.1-fold (0.32 log units) above; the measured number lies below the stated range.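

In this assay, methoxy in place of amino on an aromatic carbon gave a 3.7-fold lower number from compound 2 to compound 4 (0.57 log units; beyond the scatter). Set beside the earlier use of this change, the result gives no sign that the two cores respond differently: the same change on two cores in this assay, a 1.8-fold lower number (0.25 log units; within the scatter) from compound 1 to compound 3 and a 3.7-fold lower number (0.57 log units; beyond the scatter) from compound 2 to compound 4, 2.1-fold (0.33 log units) apart, within the scatter of two such steps. Within these two pairs the change carries from one core to the other without a difference that can be told from scatter, but two pairs do not show that its size is fixed or that it would hold on a further core, and they cannot separate the role of the core from that of the place where the group sits.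

The compounds shown leave open whether other groups at the same place, such as an ethoxy group, a fluorine or a carboxylic acid, would fall in line with methoxy or amino. They also leave open how the series would respond if the hydroxy group on the other ring were exchanged for an amide or a longer chain.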